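Pentylamino to Chloroanilino on the Aminopyridine Amide

This account rests on a few compounds, and the source may have more. Where it says the series, first, only, none or still open, it means among the compounds named here.

Compound 1 `C=C(C)COc1ccc(C(=O)Nc2cccc(C)n2)cc1` gives 19600 nM in an in vitro assay on HEK-tsA201 cells for antagonist activity at Neuronal acetylcholine receptor; alpha4/beta2 (Homo sapiens), read by fluorescence and calcium flux; a higher number here means a weaker inhibitor, a lower number a stronger inhibitor.
Compound 2 `CCCCCNc1cccc(NC(=O)c2ccc(OCCC)cc2)n1` gives > 100000 nM in this assay.

Compound 2 stands at the edge of what this assay reports: for compound 2 the reading > 100000 nM is a limit of the assay and not a number (the limit of > 100000 nM in this assay, at which 1 of the 2 values shown sits). Among the measured compounds shown here, only compound 1 carries a measured value here, so no step between measured compounds is available to calibrate the change that follows.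

Compound 3 `CCCOc1ccc(C(=O)Nc2cccc(Nc3ccc(Cl)cc3)n2)cc1` differs from compound 2 in one place: 4-chlorophenyl in place of pentyl on a nitrogen on an aromatic ring. For the measured compounds named here, with no measured step of this kind to lean on, the size and direction of the effect are open; the change could leave compound 3 at the limit as well, or bring it into the measurable range.

Compound 3 is expected to give about 50000 nM in this assay, with a range from 10000 nM to 250000 nM. The expected step is an at least 2.0-fold lower number from compound 2 to compound 3 (0.30 log units; that floor lies within the scatter), and it is an estimate carrying a fair chance that only a limit is reported.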

Compound 3, half-maximal inhibitory concentration: > 100000 nM
Compound 3 was reported as a limit (the forecaster's own chance of this, stated with the estimate: 45%); middle value at least 2.0-fold (0.30 log units) away from the limit.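

Compound 2 and compound 3 are both reported only as limits, so no step between them can be read: the limit of > 100000 nM in this assay, at which 2 of the 3 values shown sit.

The compounds shown leave open whether 4-chlorophenyl in place of pentyl changes inhibition at all, since neither compound has a measured number.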